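Trifluoromethyl on the benzyl of an Akt inhibitor

The source may hold more compounds than are shown below. What is called first, only, known or untested is meant among the compounds shown, and "the series" means these compounds.

Measured compounds:
- compound 1, `O=C(NC(c1cnc(Cl)c(Cl)c1)C1CCNCC1)c1ccc2cnccc2c1`: 140 nM
- compound 2, `O=C(NC(c1ccc(Cl)c(Cl)c1)C1CCNCC1)c1ccc2cnc(F)cc2c1`: 20 nM
- compound 3, `O=C(N[C@@H](c1ccc(Cl)c(Cl)c1)C1CCN(Cc2ccccc2)CC1)c1ccc2cnccc2c1`: 240 nM

In an assay on isolated protein for inhibition of RAC-alpha serine/threonine-protein kinase (Homo sapiens) (a higher number here means a weaker inhibitor, a lower number a stronger inhibitor), compound 3 gives the highest of the three numbers. Its nearest neighbour is compound 1, whose number is lower by an amount within the scatter, so the two cannot be told apart; compound 2 has a clearly lower number, beyond the scatter.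

Compound 4, `O=C(N[C@@H](c1ccc(Cl)c(Cl)c1)C1CCN(Cc2ccc(C(F)(F)F)cc2)CC1)c1ccc2cnccc2c1`, differs from compound 3 in one place: trifluoromethyl in place of hydrogen on an aromatic carbon. Within the data shown here, since no pair of measured compounds shows the effect of this change, the expectation rests only on compound 3. The step of a 1.0-fold higher number from compound 3 to compound 4 (0.02 log units; within the scatter) is expected to stay within the scatter, with no clear direction. For compound 4 the estimate in this assay is 250 nM, with a range from 80 nM to 800 nM.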

Compound 4, half-maximal inhibitory concentration: 2300 nM
Compound 4: the middle estimate sits 9.2-fold (0.96 log units) below what was measured; the measured number lies above the stated range.
By their numbers in this assay, from the lowest: compound 2; then compounds 1 and 3 (each within the scatter of the next); then compound 4.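

In this assay, replacing benzyl with 4-(trifluoromethyl)benzyl gives a 9.6-fold higher number from compound 3 to compound 4 (0.98 log units; beyond the scatter) and so weakens inhibition. The earlier compounds shown here offered no comparison at this position, and this pair shows that a change on the benzyl can clearly shift the result. Nothing available explains the loss.

As far as these compounds go, it remains open whether the loss is specific to trifluoromethyl or would also follow with a methyl, a methoxy or an amine at the same place. A single pair also cannot show whether the same change would weaken inhibition on other compounds.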